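A few compounds are considered here, and "the series" means these few. Any claim that something is new, unique, unknown or untested is made for them only; others in the source may bear on it.

Compound 1 `C[C@H](NC(=O)c1cn(Cc2ccc(C(F)(F)F)cc2)nn1)c1ccc(C(=O)O)cc1` and compound 2 `C[C@H](NC(=O)c1c(-c2ccccc2)nnn1Cc1ccc(F)c(F)c1)c1ccc(C(=O)O)cc1` are the two measured compounds.

In a functional assay on CHO cells for antagonist activity at prostaglandin E2 receptor EP4 subtype (Homo sapiens), read by calcium flux, with a stated time of 15 min (a lower number here means a stronger inhibitor, a higher number a weaker inhibitor), compound 1 gives only a limit, > 10000 nM. For compound 1 this entry is a limit (the limit of > 10000 nM in this assay, at which 1 of the 2 values shown sits). In this assay, within the data shown here, compound 2 gives 148 nM, the only actual number recorded. Compound 3 `COc1cccc(Cn2nnc(-c3ccccc3)c2C(=O)N[C@@H](C)c2ccc(C(=O)O)cc2)c1` differs from compound 2 by 3-methoxyphenyl in place of 3,4-difluorophenyl on a saturated chain carbon bound to an aromatic nitrogen. Among the measured compounds shown here, no step between two measured compounds is available, so the step is expected to be small, a 1.4-fold higher number from compound 2 to compound 3 (0.13 log units; within the scatter), and within the usual scatter. In this assay compound 3 is estimated at 200 nM, between 60 nM and 700 nM.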

Compound 3, half-maximal inhibitory concentration: 96.8 nM
Estimate against measurement, compound 3: 2.1-fold (0.32 log units) above, within the range that was stated.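

The step at this place, a 1.5-fold lower number from compound 2 to compound 3 (0.18 log units; within the scatter) in this assay, is the only comparison shown between compounds that differ in one place. It shows that, on a saturated chain carbon bound to an aromatic nitrogen, 3-methoxyphenyl and 3,4-difluorophenyl are not told apart by this read-out. Nothing given here offers a measured reason for this result. What the compounds shown leave open is how an amine on this ring would read. A longer chain between the ring and the aromatic nitrogen also remains untested in what is shown here.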